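From compound 2 to compound 4: a 3-hydroxyoxetan-3-yl swap

The source may hold more compounds than are shown below. What is called first, only, known or untested is meant among the compounds shown, and "the series" means these compounds.

In an ADME assay on microsomes from liver (Homo sapiens) for pharmacokinetics (on this read-out higher numbers stand for fast clearance and lower numbers for slow clearance), compound 1 `Cc1c(Nc2nc(N)c3c(C#N)c(N4CCC[C@H]4C)n(C)c3n2)cnn1C` gives 41.7 mL/min/kg, compound 3 `C[C@@H]1CCCN1c1c(C#N)c2c(N)nc(Nc3cn(C)nc3C(F)(F)F)nc2n1C` gives 33.3 mL/min/kg and compound 2 `Cc1nn(CC(C)(C)O)cc1Nc1nc(N)c2c(C#N)c(N3CCC[C@H]3C)n(C)c2n1` gives 50 mL/min/kg. Compound 2 thus stands within the scatter of both other compounds, so the three numbers show no order.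

Compound 4 `Cc1nn(CC2(O)COC2)cc1Nc1nc(N)c2c(C#N)c(N3CCC[C@H]3C)n(C)c2n1` differs from compound 2 in one group: 3-hydroxyoxetan-3-yl in place of 1-hydroxy-1-methylethyl on a saturated chain carbon bound to an aromatic nitrogen. In words, 3-hydroxyoxetan-3-yl takes the place of 1-hydroxy-1-methylethyl on a saturated chain carbon bound to an aromatic nitrogen.

For the measured compounds named here, no measured step covers this change. Going by the values given here, the only single-place step, a 1.3-fold lower number from compound 1 to compound 3 (0.10 log units; within the scatter), concerns a different group and stays within the scatter. It offers no direct guide, though it shows this assay moving little across this small set. No shift beyond the scatter is therefore expected. The expected change is a 1.3-fold lower number from compound 2 to compound 4 (0.12 log units; within the scatter), an estimate whose direction is only weakly supported. For compound 4 the estimated value is 38 mL/min/kg, with an expected range from 20 mL/min/kg to 62 mL/min/kg.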

Compound 4, clearance: 76.7 mL/min/kg
Compound 4: middle estimate off by 2.0-fold (0.31 log units), on the low side; the measured number lies above the stated range.
By their numbers in this assay, from the lowest: compounds 3, 1, 2 and 4 (each within the scatter of the next, the first and the last beyond it).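

For the compounds shown here, this is the first step read at the saturated chain carbon bound to an aromatic nitrogen, since the earlier step concerned a different group. In this assay the swap to 3-hydroxyoxetan-3-yl, which brings a four-membered non-aromatic ring and a second hydrogen-bond acceptor, comes with a 1.5-fold higher number from compound 2 to compound 4 (0.19 log units; within the scatter) and so does not separate the two compounds on this read-out. Nothing available explains the result or ties it to any property of either group.

As far as these compounds go, what a carboxylic acid, an amine or a longer chain would give at this place stays open. From the compounds shown here alone, whether the swap reads the same with other groups elsewhere on the shared core also stays open, as it rests on this single pair.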